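Series notes: aryl swap on the saturated ring carbon

The source may hold more compounds than are shown below. What is called first, only, known or untested is meant among the compounds shown, and "the series" means these compounds.

Compound 1 `CNC(=O)c1cc(C(=O)N[C@H]2C[C@@H]2C)cc2c1OC[C@H]2c1ccccc1` gives 4.5 in a physicochemical assay for lipophilicity, at pH 7.4; a higher number here means a more lipophilic compound, a lower number a more polar compound.
Compound 2 `CNC(=O)c1cc(C(=O)N[C@H]2[C@@H]3C[C@@H](O)C[C@@H]32)cc2c1OC[C@@]2(C)c1ccccc1` gives 3.3 in this assay.
Compound 3 `CNC(=O)c1cc(C(=O)NC2CC2)cc2c1OC[C@H]2c1cccc(OC)c1` gives 3.8 in this assay.

Compound 3 holds the second highest of the three numbers: compound 2 lies lower, beyond the scatter, and compound 1 lies higher, also beyond the scatter. Compound 4 `CNC(=O)c1cc(C(=O)NC2CC2)cc2c1OC[C@H]2c1ccc(F)cc1` has not yet been measured. It differs from compound 3 in one place: 4-fluorophenyl in place of 3-methoxyphenyl on a saturated ring carbon. Going by the values given here, no step between two measured compounds isolates this change, so nothing in the measured set fixes its size. A modest rise is expected, probably just beyond the scatter. Compound 4 is expected to give 4.2, in the range 3.8 to 4.6. The step expected is a number 0.40 log units higher from compound 3 to compound 4 (beyond the scatter).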

Compound 4, distribution coefficient: 3.8
Compound 4: the middle estimate sits 0.40 log units above what was measured; measured number inside the range.
By their numbers in this assay, from the lowest: compound 2; then compounds 3 and 4 (each within the scatter of the next); then compound 1.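

In this assay, 4-fluorophenyl in place of 3-methoxyphenyl on a saturated ring carbon gives no change at the digits printed from compound 3 to compound 4 (within the scatter) at this position. Going by these compounds alone, this pair is the first to isolate the aryl group here, and the number holds although 7 heavy atoms replace 8 and the hydrogen-bond acceptor of the methoxy group is gone. Nothing at hand accounts for the two groups reading alike.

One pair cannot show whether other aryl groups at this carbon would read the same. Also open, as far as these compounds go, is how an aminophenyl or a carboxyphenyl group would read at this position.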